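Changing the Aromatic Group on the Ring Amine Nitrogen

A few compounds are considered here, and "the series" means these few. Any claim that something is new, unique, unknown or untested is made for them only; others in the source may bear on it.

Compound 1 `CCCc1nc(-c2ccccc2)c(CNCCCN2CCN(c3ccc(F)cc3)CC2)o1`: 3210 nM
Compound 2 `CCCc1nc(-c2ccccc2)c(CNCCCN2CCN(c3ccccc3Cl)CC2)o1`: 2800 nM
Compound 3 `CCCc1nc(-c2ccccc2)c(CNCCCN2CCN(c3cccc(Cl)c3)CC2)o1`: 1750 nM

In an assay on HEK293 cells for inhibition of Voltage-dependent T-type calcium channel subunit alpha-1G (Homo sapiens), read by patch clamp (on this read-out higher numbers stand for weaker inhibition and lower numbers for stronger inhibition), compound 3 gives the lowest of the three numbers, yet it sits within the scatter of both others: a 1.8-fold lower number from compound 1 to compound 3 (0.26 log units; within the scatter) and a 1.6-fold lower number from compound 2 to compound 3 (0.20 log units; within the scatter). The step of a 1.1-fold lower number from compound 1 to compound 2 (0.06 log units; within the scatter) is likewise within the scatter. Compound 4 `CCCc1nc(-c2ccccc2)c(CNCCCN2CCN(c3ccc(C(F)(F)F)cc3)CC2)o1` differs from compound 3 in the same part of the molecule: 4-(trifluoromethyl)phenyl in place of 3-chlorophenyl on an amine nitrogen in a ring. Every measured change of this aromatic group has left the read-out essentially unmoved, so no step beyond the scatter is expected here either, and the estimated step of a 1.3-fold higher number from compound 3 to compound 4 (0.10 log units; within the scatter) reflects that. Compound 4 is therefore expected to give about 2200 nM, with a plausible range from 1000 nM to 5000 nM.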

Compound 4, half-maximal inhibitory concentration: 7250 nM
For compound 4 the middle estimate is 3.3-fold (0.52 log units) below the measured one; the whole stated range lies below it.
By their numbers in this assay, from the lowest: compounds 3, 2 and 1 (each within the scatter of the next); then compound 4.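

Among these compounds, this position is not indifferent to its aromatic group: in this assay, 4-(trifluoromethyl)phenyl brings the only steps beyond the scatter here, all modest and toward weaker inhibition (a 4.1-fold higher number from compound 3 to compound 4 (0.62 log units; beyond the scatter)) (a 2.6-fold higher number from compound 2 to compound 4 (0.41 log units; beyond the scatter)). Swapping just the fluoro for trifluoromethyl on the aromatic carbon is enough to move the number (a 2.3-fold higher number from compound 1 to compound 4 (0.35 log units; beyond the scatter)). Nothing available explains this shift.

Going by these compounds, whether the trifluoromethyl group would have the same effect elsewhere on the aromatic ring remains open. So does the outcome with a methoxy group, a nitrile or a pyridine ring.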